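The source may report more compounds than this note shows. Statements on the series, on what has been measured and on what is new or still open speak of the compounds shown alone.

Of the compounds shown here, three with a shared core have been measured in a functional assay on PC-3 cells (Homo sapiens) for inhibition, read by sulforhodamine B assay, with a stated time of 72 h; a lower number here means a stronger inhibitor, a higher number a weaker inhibitor. Compound 1 `CCOC(=O)Nc1sc(-c2ccc(Cl)cc2)c(-c2ccc(Cl)cc2)c1C(=O)NC1CC1` gives 27600 nM. Compound 3 `CC(=O)Nc1sc(-c2ccc(Cl)cc2)c(-c2ccc(Cl)cc2)c1C(=O)N1CCCCC1` gives 10300 nM. Compound 2 `CCCCNC(=O)c1c(N)sc(-c2ccc(Cl)cc2)c1-c1ccc(Cl)cc1` gives 17800 nM, a number that sits between those of compound 1 and compound 3; both of its gaps to them, however, lie within the usual scatter of repeated measurements, so the three compounds cannot be ranked against each other on these numbers alone.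

Compound 4 `Nc1sc(-c2ccc(Cl)cc2)c(-c2ccc(Cl)cc2)c1C(=O)N1CCNCC1` has not yet been measured in this assay . It differs from compound 2 in a single place:

piperazin-1-yl in place of butylamino on a carbonyl carbon

Within the data shown here, no pair of measured compounds differs by only one group, so nothing measured here shows how a change of this kind moves the number. The step of a 1.1-fold lower number from compound 2 to compound 4 (0.05 log units; within the scatter) is therefore expected to stay within the scatter, with no clear direction. Compound 4 is expected to give about 16000 nM, with a range from 5000 nM to 50000 nM.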

Compound 4, half-maximal inhibitory concentration: 2710 nM
For compound 4 the middle estimate is 5.9-fold (0.77 log units) above the measured one; measured number outside the range, below it.
By their numbers in this assay, from the lowest: compound 4; then compounds 3, 2 and 1 (each within the scatter of the next, the first and the last beyond it).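

In this assay, among these compounds, the group on the carbonyl carbon proves able to move the number: piperazin-1-yl in place of butylamino gives a 6.6-fold lower number from compound 2 to compound 4 (0.82 log units; beyond the scatter), the first single-group step that can be read in this set. The group that leaves has no ring, while the one that enters is a six-membered non-aromatic ring with 2 hetero atoms. No measurement at hand tells what lies behind this step.

This one step cannot separate the effect of having a ring from that of having the second ring nitrogen; morpholin-4-yl, which has oxygen in place of that nitrogen, on the same carbonyl carbon would help to tell them apart. Going by these compounds, how far the change carries over to compounds with an acyl group on the core's amino group also remains open.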